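Aryl sulfonate anilides: iodo for isopropyl step

This account rests on a few compounds, and the source may have more. Where it says the series, first, only, none or still open, it means among the compounds named here.

Of the compounds shown here, two of this sulfonate anilide series carry a number so far. Compound 1 `CC(C)C(=O)Nc1ccc(S(=O)(=O)Oc2ccccc2I)cc1` gives 3300 nM in a functional assay on HT-1080 cells (Homo sapiens) for antiproliferative activity, read by sulforhodamine B assay, with a stated time of 48 h; a lower number here means a stronger inhibitor, a higher number a weaker inhibitor. Compound 2 `CC(C)c1ccccc1OS(=O)(=O)c1ccc(NC(=O)CCCl)cc1` gives 6500 nM in this assay; this is the higher of the two numbers, but compound 1 lies within the scatter of it, so no order between the two can be stated. Within the data shown here, no single-change step between measured compounds exists in the set.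

Compound 3 `O=C(CCCl)Nc1ccc(S(=O)(=O)Oc2ccccc2I)cc1` is not yet measured. It differs from compound 2 by iodo in place of isopropyl on an aromatic carbon, on an aromatic carbon of a six-membered aromatic ring of carbon only, ortho to a large group; the chloropropanoyl amide of compound 2 is kept. Among the measured compounds shown here, the iodo-bearing sulfonate ester is the one also present in compound 1, whose number in this assay is 3300 nM.

Expectation: a step in this assay toward a lower number, of modest size and possibly not beyond the scatter, is estimated as a 1.6-fold lower number from compound 2 to compound 3 (0.21 log units; within the scatter). Compound 3 is accordingly expected to give about 4000 nM, within a range from 1500 nM to 11000 nM.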

Compound 3, half-maximal inhibitory concentration: 4200 nM
Compound 3: the middle estimate sits 1.1-fold (0.02 log units) below what was measured, within the range that was stated.
By their numbers in this assay, from the lowest: compounds 1, 3 and 2 (each within the scatter of the next).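

In this assay, among these compounds, iodo in place of isopropyl on an aromatic carbon, ortho to a large group, gives a 1.5-fold lower number from compound 2 to compound 3 (0.19 log units; within the scatter) and so, for the first time, this position is compared with only that one change, and the two groups are not separated here even though 3 carbon heavy atoms give way to 1 iodine. With iodo held in place, 2-chloroethyl in place of isopropyl on a carbonyl carbon gives a 1.3-fold higher number from compound 1 to compound 3 (0.10 log units; within the scatter) and the amide end of the series is likewise not separated, so neither single change yet moves the number beyond the scatter. No accompanying measurement speaks to what lies behind either step.

Going by these compounds, both steps rest on a single pair each, so it remains open whether a group of another kind on the same aromatic carbon, such as an amine or a carboxylic acid, would give a step beyond the scatter. The same question stands for the carbonyl carbon, where a longer chain or a ring-bearing group could be compared with 2-chloroethyl and isopropyl.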